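Dropping the butyl chain from a cytotoxic nucleoside analogue

This account rests on a few compounds, and the source may have more. Where it says the series, first, only, none or still open, it means among the compounds named here.

Measured compounds:
compound 1 `CCCCc1ccc(-c2cc(-c3cn([C@H]4C[C@H](OC(C)=O)[C@@H](COC(C)=O)O4)c(=O)[nH]c3=O)on2)cc1` gives 80.5%
compound 2 `O=c1[nH]c(=O)n([C@H]2C[C@H](O)[C@@H](CO)O2)cc1-c1cn(Cc2ccccc2)nn1` gives 98.7%
compound 3 `CC(C)(C)c1ccc(-c2cc(-c3cn([C@H]4C[C@H](O)[C@@H](CO)O4)c(=O)[nH]c3=O)on2)cc1` gives 94.2%

Of the compounds shown here, three have been tested in a functional assay on ACHN cells (Homo sapiens) for cytotoxicity, read by sulforhodamine B assay, tested at 10 uM; on this read-out higher numbers stand for more inhibition at the one concentration tested (going by the name of the read-out) and lower numbers for less inhibition. Compound 1 stands lowest of the three: its number lies beyond the usual scatter below both compound 3, the nearer of the two, and compound 2, the further. All three share the same deoxyribose-linked core, and compounds 1 and 3 also share a five-membered heteroaromatic ring carrying a substituted phenyl group.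

Compound 4 `CC(=O)OC[C@H]1O[C@@H](n2cc(-c3cc(-c4ccccc4)no3)c(=O)[nH]c2=O)C[C@@H]1OC(C)=O` has not yet been measured. It differs from compound 1 in a single spot: hydrogen in place of butyl on an aromatic carbon. Among the compounds with values here, no pair of measured compounds differing in just one place is available, so the effect of this change cannot be read from the data at hand. Compound 3 carries a different branched group at the corresponding spot and also lacks the acetyl groups, so it offers no clean comparison either.

Given that, the step from compound 1 to compound 4 is expected to be small, most likely a modest drop or none beyond the scatter, a number 8.5 percentage points lower from compound 1 to compound 4 (within the scatter). Compound 4 is therefore estimated to give 72% in this assay, within a range from 45% to 95%.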

Compound 4, a percentage reported as inhibition, at one concentration (the size of the read-out at that concentration, not a potency): 97.6%
Compound 4: middle estimate off by 25.6 percentage points, on the low side; measured number outside the range, above it.
By their numbers in this assay, from the lowest: compound 1; then compounds 3, 4 and 2 (each within the scatter of the next).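

Going from 4-butylphenyl to phenyl gives the first clean reading at this spot in this assay: the change produces a number 17.1 percentage points higher from compound 1 to compound 4 (beyond the scatter). On the aromatic ring, at the carbon para to a large group, the butyl chain is therefore not needed for a high number in this series, at least while both acetyl groups remain on the sugar-like part of the molecule, and its presence goes with less inhibition at the one concentration tested. Nothing available explains why removing the four-carbon chain has this effect.

The compounds shown leave open whether the number falls gradually as the chain grows or whether a much smaller group, such as methyl, would already lower it, and whether a methoxy group or an amine at the same carbon would behave like hydrogen or like butyl. They also leave open whether this change would have the same effect with free hydroxyl groups in place of the acetyl esters, and, since only one concentration was read, how the potencies of compound 1 and compound 4 compare.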